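A few compounds are considered here, and "the series" means these few. Any claim that something is new, unique, unknown or untested is made for them only; others in the source may bear on it.

The series shares one core, a sulfonamide that carries a pyrimidinedione on one side and a phenyl ring on the other, the phenyl ring bearing a triazole with a second aryl group. Compound 1 `Cc1cccc(-n2cc(-c3ccccc3NS(=O)(=O)c3c[nH]c(=O)[nH]c3=O)nn2)c1` is measured in an ADME assay on GES1 cells (Homo sapiens) for cytotoxicity, read by MTT assay, with a stated time of 24 h (on this read-out higher numbers stand for lower toxicity in this test and lower numbers for higher toxicity in this test), and gives 23700 nM. Compound 2 `O=c1[nH]cc(S(=O)(=O)Nc2ccccc2-c2cn(-c3ccc(F)cc3)nn2)c(=O)[nH]1` is recorded in this assay as "not toxic" (no number reported), with no number attached. Compound 3 `O=c1[nH]cc(S(=O)(=O)Nc2ccc(-c3cn(-c4ccccc4)nn3)cc2)c(=O)[nH]1` is likewise recorded in this assay as "not toxic" (no number reported), so no single number places it on the scale; it is one of two entries in this set without a figure, and only compound 1 supplies a numerical point of reference.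

Compound 4 `Cc1cccc(-n2cc(-c3ccc(NS(=O)(=O)c4c[nH]c(=O)[nH]c4=O)cc3)nn2)c1` differs from compound 3 by methyl in place of hydrogen on an aromatic carbon. Among the measured compounds shown here, no measured pair in this set isolates that change, so the size of the step in this assay can only be guessed; the one numbered compound, compound 1, which also carries a 3-methylphenyl on the triazole, sits far up the scale at 23700 nM, and nothing here points to a move beyond the scatter in either direction. Compound 4 is therefore expected to give about 30000 nM, within a range of 10000 nM to 100000 nM, with a fair chance that it, too, is reported without a number.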

Compound 4, half-maximal cytotoxic concentration: 28300 nM
Compound 4: the middle estimate sits 1.1-fold (0.03 log units) above what was measured, and the stated range covers the measured number.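

In this assay, among the compounds shown here, compound 3 carries no number, so no step to compound 4 can be read from its 28300 nM. Nothing shown explains the value of compound 4. The compounds shown leave open whether methyl in place of hydrogen on an aromatic carbon moves this read-out at all.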